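The source may hold more compounds than are shown below. What is called first, only, known or untested is meant among the compounds shown, and "the series" means these compounds.

Compound 1: `COc1c(Br)cccc1C(=O)Nc1ccc(Sc2nc3ccccc3s2)c(Cl)c1` — > 100000 nM
Compound 2: `O=C(Nc1ccc(Sc2nc3ccccc3s2)cc1)c1cc(Br)ccc1O` — > 100000 nM
Compound 3: `COc1c(Br)cccc1C(=O)Nc1cccc(Cl)c1` — > 100000 nM

All three numbers come from an assay on isolated protein for inhibition of thiosulfate sulfurtransferase (Homo sapiens), with a stated time of 60 min, in the absence of a further agent; on this read-out higher numbers stand for weaker inhibition and lower numbers for stronger inhibition. For compound 1 the value > 100000 nM is a limit of the assay, not a measured number. The same holds for compound 2, whose > 100000 nM is a limit, and for compound 3, whose > 100000 nM is a limit. So compound 1 stands nowhere in particular among the three: every value shown sits at the limit of > 100000 nM in this assay, at which 3 of the 3 values shown sit, and no compound can be set apart from another.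

The next compound, compound 4 `COc1c(Br)cc(Br)cc1C(=O)Nc1ccc(Sc2nc3ccccc3s2)c(Cl)c1`, differs from compound 1 in one place: bromo in place of hydrogen on an aromatic carbon. Among the compounds with values here, no step between two measured compounds exists to suggest how such a change moves the read-out in this assay. With nothing to push the expectation either way, the step from compound 1 to compound 4 is expected to be a number no higher from compound 1 to compound 4 (the limit leaves the size open), that is, no change beyond the scatter. Compound 4 is therefore estimated at 100000 nM, within a range from 30000 nM to 300000 nM, with the real chance that the assay again reports only a limit.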

Compound 4, half-maximal inhibitory concentration: > 100000 nM
Compound 4: no number, only a limit (the forecaster's own chance of this, stated with the estimate: 75%); the middle value lies on the limit itself.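

Compound 4 gives > 100000 nM, a limit of the assay and not a number, and compound 1 also stands at a limit, so no step can be read from compound 1 to compound 4. What the added bromo does to inhibition in this assay stays open, as does any ranking of the compounds shown: the limit of > 100000 nM in this assay, at which 4 of the 4 values shown sit.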